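The source may hold more compounds than are shown below. What is called first, only, known or untested is meant among the compounds shown, and "the series" means these compounds.

Measured so far, in a functional assay on HT-29 cells (Homo sapiens) for cytotoxicity, read by MTT assay, with a stated time of 72 h; a lower number here means a stronger inhibitor, a higher number a weaker inhibitor:

Compound 1 `CN(C)CCn1cnnc1-c1cc(Oc2ccc(NC(=O)N/N=C/c3ccc(O)c(Br)c3)cc2F)ccn1`: 450 nM
Compound 2 `CN(C)CCn1cnnc1-c1cc(Oc2ccc(NC(=O)N/N=C/c3ccc(F)cc3)cc2F)ccn1`: 1370 nM
Compound 3 `CN(C)CCn1cnnc1-c1cc(Oc2ccc(NC(=O)N/N=C/c3cccc(Cl)c3Cl)cc2F)ccn1`: 130 nM

Among these three numbers compound 1 sits second highest: compound 2 gives a higher number, by a 3.0-fold higher number from compound 1 to compound 2 (0.48 log units; beyond the scatter), and compound 3 gives a lower one, by a 3.5-fold lower number from compound 1 to compound 3 (0.54 log units; beyond the scatter). Between those two, the step of an 11-fold lower number from compound 2 to compound 3 (1.02 log units; beyond the scatter) is the largest difference seen.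

Compound 4 `CN(C)CCn1cnnc1-c1cc(Oc2ccc(NC(=O)N/N=C/c3cc(Br)c(O)c(Br)c3)cc2F)ccn1` differs from compound 1 in one place: bromo in place of hydrogen on an aromatic carbon

For the measured compounds named here, none of the measured steps is of this kind. Going by the values given here, each swaps the whole aromatic ring on the carbon with a double bond to nitrogen for a differently decorated one; no step adds a single bromo to an otherwise unchanged ring. What the measured steps do show is that the pattern of groups on this ring moves the number in this assay in both directions, by modest to large amounts. Among the compounds with values here, with no direct precedent, the expectation for compound 4 is a step of at most modest size, in either direction, and probably not beyond the scatter: a 1.2-fold lower number from compound 1 to compound 4 (0.07 log units; within the scatter). The estimate for compound 4 in this assay is therefore 380 nM, expected to lie between 130 nM and 1100 nM.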

Compound 4, half-maximal inhibitory concentration: 2670 nM
Compound 4: middle estimate off by 7.0-fold (0.85 log units), on the low side, outside the stated range (above it).
By their numbers in this assay, from the lowest: compound 3; then compound 1; then compounds 2 and 4 (each within the scatter of the next).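

In this assay, a single added bromo, ortho to the hydroxy group, is enough to move the number beyond the scatter (as a 5.9-fold higher number from compound 1 to compound 4 (0.77 log units; beyond the scatter)), so this carbon of the ring is sensitive to even a one-atom change. The 3,5-dibromo-4-hydroxyphenyl ring stays within the scatter of the 4-fluorophenyl ring (with a 1.9-fold higher number from compound 2 to compound 4 (0.29 log units; within the scatter)) but lies far from the 2,3-dichlorophenyl ring (with a 21-fold higher number from compound 3 to compound 4 (1.31 log units; beyond the scatter)), so carrying two halogens does not by itself set the number. No measurement available here explains why the added bromo has this effect. Still open, going by these compounds, is whether a chloro or a methyl on this same carbon would move the number as bromo does. A methoxy in place of the hydroxy group, with or without the added bromo, is also untested among these compounds.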